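This account rests on a few compounds, and the source may have more. Where it says the series, first, only, none or still open, it means among the compounds named here.

Measured so far in an in vitro functional assay on cells for agonist activity at Bombesin receptor subtype-3 (Mus musculus), read by luminescence and calcium flux; a higher number here means that more compound is needed for the effect, a lower number that less compound is needed:
- compound 1, `O=C(O)c1ccccc1-c1ccc(CCc2ncc(CC3CCCC3)[nH]2)cc1`, gives 7.9 nM
- compound 2, `O=C(O)c1ccccc1-c1ccc(CCc2ncc(Cc3ccccc3F)[nH]2)cc1`, gives 9.5 nM

For the measured compounds named here, compound 1 holds the lower of the two numbers, but its only neighbour is compound 2 and the step of a 1.2-fold higher number from compound 1 to compound 2 (0.08 log units; within the scatter) is within the scatter, so the two cannot be ordered. Compound 3, `CCCCc1cnc(CCc2ccc(-c3ccccc3C(=O)O)cc2)[nH]1`, remains to be measured. Against compound 1 the change is propyl in place of cyclopentyl on a saturated chain carbon bound to an aromatic carbon. Going by the values given here, the single measured step at this same place, a 1.2-fold higher number from compound 1 to compound 2 (0.08 log units; within the scatter), shows that swapping the cyclopentyl for a ring of another kind changed nothing beyond the scatter. Among the compounds with values here, that is the only guidance; no measured pair tells what happens when the ring is removed altogether and a short open chain stands in its place, and the propyl is the smallest group yet put on this saturated chain carbon bound to an aromatic carbon. On this basis compound 3 is expected to sit near compound 1, with at most a modest shift toward a higher number, a 1.9-fold higher number from compound 1 to compound 3 (0.28 log units; within the scatter). The estimate for compound 3 is 15 nM, with a range from 5 nM to 50 nM.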

Compound 3, half-maximal effective concentration: 93 nM
Compound 3: middle estimate off by 6.2-fold (0.79 log units), on the low side, outside the stated range (above it).
By their numbers in this assay, from the lowest: compounds 1 and 2 (each within the scatter of the next); then compound 3.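

In this assay the earlier pair made this position look tolerant, but the group on a saturated chain carbon bound to an aromatic carbon does matter: propyl in place of cyclopentyl gives a 12-fold higher number from compound 1 to compound 3 (1.07 log units; beyond the scatter) and propyl in place of 2-fluorophenyl gives a 9.8-fold higher number from compound 2 to compound 3 (0.99 log units; beyond the scatter) at the same place. Among these three compounds, the two carrying a ring in this group stand within the scatter of each other, while the one carrying the open chain stands apart from both, and no compound shown goes against this split. Nothing on hand explains the shift.

The change to propyl removes the ring and also reduces the heavy atoms, and the compounds shown cannot separate these two differences; a longer open chain such as pentyl or hexyl, set against a small ring such as cyclopropyl, would bear on that question. Also open, going by these compounds, is how far the ring itself can vary at this place, for instance a cyclohexyl, or a pyridine in place of the 2-fluorophenyl.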